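The source may hold more compounds than are shown below. What is called first, only, known or untested is meant among the compounds shown, and "the series" means these compounds.

Measured so far:
compound 1 `CCCCCCCCCCCOc1ccccc1CCC(=O)OCc1ccccc1OP(=O)(O)OC[C@H](N)C(=O)O` — 0.02
compound 2 `N[C@@H](COP(=O)(O)OC[C@H]1OCC=C[C@H]1OC(=O)CCc1ccccc1OCc1cccc(Oc2ccccc2)c1)C(=O)O` — "not active" (no number reported)

In an assay on HEK293-A cells with putative P2Y purinoceptor 10 (Mus musculus) as the target, with a stated time of 1.5 h (on this read-out lower numbers stand for smaller maximal responses and higher numbers for larger maximal responses), compound 1 gives 0.02. In this assay compound 2 is reported as "not active" (no number reported), so no single number marks where it stands; it is known only as inactive. Compound 3 `N[C@@H](COP(=O)(O)OC[C@H]1OCC=C[C@@H]1OC(=O)CCc1ccccc1OCc1cccc(Oc2ccccc2)c1)C(=O)O` differs from compound 2 in one respect: the two compounds have the same atoms and bonds; at least one stereo element is drawn with a configuration in one of them and without one in the other: 1 of 4 stereo elements differ; a stereocentre at a saturated ring carbon is drawn R in compound 2 and S in compound 3. For the measured compounds named here, no measured pair shows what such a change does in this assay, so any expected step is an open guess; a move beyond the scatter in either direction cannot be ruled out, but none is assumed. Compound 3 is therefore expected to give about 0.05, in a range from 0 to 0.2.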

Compound 3, intrinsic activity: the largest response reached, as a fraction of the reference agonist's: "not active" (no number reported)
Nothing numeric was reported for compound 3, and the estimate cannot be compared.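

Compound 2 and compound 3 are both reported as not active in this assay, so no step can be read between them. Still open, going by these compounds, is whether the stereocentre at the saturated ring carbon affects the maximal response at all, and the comparison carries a caveat: the fact that one of compounds 2 and 3 is drawn with a defined configuration and the other without, at the place where they differ.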